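Swapping the aryl hydrazone of a quinolone: fluorophenyl to nitrophenyl

This account rests on a few compounds, and the source may have more. Where it says the series, first, only, none or still open, it means among the compounds named here.

Measured compounds:
Compound 1 `COc1ccc(/C=N/NC(=O)c2cn(C3CC3)c3cc(N4CCNCC4)c(F)cc3c2=O)cc1O`: in a functional assay on L1210 cells (Mus musculus) for antiproliferative activity, read by MTT assay (a higher number here means a weaker inhibitor, a lower number a stronger inhibitor), compound 1 gives <= 25000 nM, which is a limit of the assay.
Compound 2 `O=C(N/N=C/c1ccc(F)cc1)c1cn(C2CC2)c2cc(N3CCNCC3)c(F)cc2c1=O`: in this assay compound 2 gives <= 25000 nM, likewise a limit of the assay.

Compound 2 thus stands at the limit where both measured values sit (the limit of <= 25000 nM in this assay, at which 2 of the 2 values shown sit). Compound 3 `O=C(N/N=C/c1ccccc1[N+](=O)[O-])c1cn(C2CC2)c2cc(N3CCNCC3)c(F)cc2c1=O` differs from compound 2 in one place: 2-nitrophenyl in place of 4-fluorophenyl on a carbon with a double bond to nitrogen. For the measured compounds named here, the only measured step, a step that the two limits leave unreadable from compound 1 to compound 2, also exchanges the aryl group on the same carbon, yet its size cannot be read from two limits. Going by the values given here, no step with a readable size therefore bears on this change. The expected step is set near zero, as a step that the limit leaves unreadable from compound 2 to compound 3. Compound 3 is expected to give 20000 nM, within 5000 nM to 25000 nM, most probably again as a limit.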

Compound 3, half-maximal inhibitory concentration: <= 25000 nM
Compound 3: only a limit was reported (the forecaster's own chance of this, stated with the estimate: 70%); the middle value is on the limit's open side.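

The steps among compound 1, compound 2 and compound 3 cannot be read, since all three values are limits: the limit of <= 25000 nM in this assay, at which 3 of the 3 values shown sit.

The compounds shown leave open whether the aryl group on the carbon with a double bond to nitrogen changes activity in this assay at all.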